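Acetate removal in a cyclopentenone and oxime series

The source may report more compounds than this note shows. Statements on the series, on what has been measured and on what is new or still open speak of the compounds shown alone.

Compound 1 `COc1ccc(C2=C(c3cc(OC)c(OC)c(OC)c3)C(=O)C(O)C2)cc1Cl` carries a free hydroxyl on its ring; in an ADME assay on MIA PaCa-2 cells (Homo sapiens) for cytotoxicity, read by MTT assay, with a stated time of 72 h (on this read-out higher numbers stand for weaker inhibition and lower numbers for stronger inhibition), compound 1 reaches only a limit, > 100 ug/mL, which is the assay limit of > 100 ug/mL in this assay, at which 1 of the 3 values shown sits, and not a number. Compound 2 `COc1ccc(C2=C(c3cc(OC)c(OC)c(OC)c3)C(=O)C(OC(C)=O)C2)cc1Cl` is its acetate; in this assay compound 2 gives 24 ug/mL. Compound 3 `CC(=O)OC1C/C(=N/O)C(c2ccccc2)=C1c1ccccc1`, an oxime with two unsubstituted phenyl rings, gives 4.5 ug/mL in this assay, the lowest number among the measured compounds. The difference between the core of compound 2 and the core of compound 3 is not broken down here.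

The change from compound 2 to compound 1, (hydrogen in place of acetyl on an oxygen on a saturated carbon), gave an at least 4.1-fold higher number from compound 2 to compound 1 (0.61 log units; beyond the scatter), so the free hydroxyl reads as the weaker partner in that pair.

Compound 4 `O/N=C1/CC(O)C(c2ccccc2)=C1c1ccccc1` has not yet been measured. It differs from compound 3 by hydrogen in place of acetyl on an oxygen on a saturated carbon, the same change as from compound 2 to compound 1, at the same kind of position. For the measured compounds named here, with only one measured step of this kind and that step resting partly on a limit, the size is uncertain, but the direction taken from compound 2 to compound 1 is the only guide. Compound 4 is therefore expected to give a higher number than compound 3 in this assay, an estimated 5.6-fold higher number from compound 3 to compound 4 (0.74 log units; beyond the scatter). The estimate for compound 4 in this assay is 25 ug/mL, between 7 ug/mL and 100 ug/mL.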

Compound 4, half-maximal inhibitory concentration: > 100 ug/mL
Compound 4 ended at the assay's limit; the forecaster's own chance of this, stated with the estimate: 20%; at least 4.0-fold (0.60 log units) between middle value and limit.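

In this assay, acetyl replaced by hydrogen on the oxygen on a saturated carbon moved the number the same way on the second core as on the first, with an at least 22-fold higher number from compound 3 to compound 4 (1.34 log units; beyond the scatter), so the direction seen with an at least 4.1-fold higher number from compound 2 to compound 1 (0.61 log units; beyond the scatter) carried over to the oxime core of compound 3. Set side by side, the two steps do not establish a common size or a difference in size: the same change on two cores in this assay, an at least 4.1-fold higher number (0.61 log units; beyond the scatter) from compound 2 to compound 1 and an at least 22-fold higher number (1.34 log units; beyond the scatter) from compound 3 to compound 4; the limit leaves it open whether they differ Compound 4 gives > 100 ug/mL, which is a limit of the assay and not a number, so the notes can record a shared direction on two cores but no size that can be carried from one core to the next: the limit of > 100 ug/mL in this assay, at which 2 of the 4 values shown sit.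

The compounds shown hold only acetoxy and hydroxy at this oxygen, so it stays open whether a longer ester such as a butyrate, a methyl ether or an amine at the same place would give numbers nearer those of compound 2 and compound 3 or fall at the limit. As far as these compounds go, compound 2 and compound 3 differ in more than one place, so what the oxime alone contributes on a shared set of aryl rings also remains open.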